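Aryl amide variation on the shared core: compound 4

The compounds below may be only part of what the source reports. "The series", "measured", "known", "first", "only" and "open" are said of these compounds alone.

The shared core of compound 1 `O=C(CSc1nc2cccnc2[nH]1)Nc1ccccc1Cl` is tested in an assay on isolated protein for inhibition of Ectonucleotide pyrophosphatase/phosphodiesterase family member 1 (Homo sapiens), tested at 10 uM (a higher number here means more inhibition at the concentration tested (going by the name of the read-out), a lower number less inhibition), where compound 1 gives 19%. Among the three measured compounds this is the second highest number. Within the data shown here, compound 2 `Cc1ccc(NC(=O)CSc2nc3cccnc3[nH]2)c(Cl)c1` gives 2% in this assay, the only single-place step in the set, a number 17 percentage points lower from compound 1 to compound 2 (beyond the scatter). Among the measured compounds shown here, compound 3 `COc1ccc(NS(=O)(=O)CSc2nc3ncccc3[nH]2)cc1OC` gives 50% in this assay; it carries a different linker as well as a different aryl group, so no single-place step connects it to compound 1, and its value shows only that a more strongly inhibiting member exists.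

Compound 4 `O=C(CSc1nc2cccnc2[nH]1)Nc1ccc(F)cc1` differs from compound 1 in one place: 4-fluorophenyl in place of 2-chlorophenyl on an amide-type nitrogen. For the measured compounds named here, no measured step exchanges one aryl ring for another on the amide-type nitrogen, so the only step bearing on this change is the modest drop from compound 1 to compound 2, which came from adding a methyl to the aryl ring. On that basis a step in this assay no larger than the scatter is expected for the exchange to 4-fluorophenyl, with the direction open, giving a number 4 percentage points lower from compound 1 to compound 4 (within the scatter) as the estimated step. Compound 4 is estimated at 15% in this assay, with a range from 0% to 35%.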

Compound 4, a percentage reported as inhibition, at one concentration (the size of the read-out at that concentration, not a potency): 30%
Estimate against measurement, compound 4: 15 percentage points below; the measured number falls inside the stated range.
By their numbers in this assay, from the lowest: compound 2; then compound 1; then compound 4; then compound 3.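

In this assay, among these compounds, the exchange of 2-chlorophenyl for 4-fluorophenyl on the amide-type nitrogen gives a number 11 percentage points higher from compound 1 to compound 4 (beyond the scatter) and shows that the aryl group at this position can also raise the number; until now, the only single-place reading was the fall of a number 17 percentage points lower from compound 1 to compound 2 (beyond the scatter) on adding a methyl. The two aryl groups have the same ring and the same heavy-atom and hydrogen-bond counts, so the step arises with those counts unchanged, while the halogen and its place on the ring both differ. Nothing measured here gives a reason for the step.

Going by these compounds, it remains open whether the halogen itself or its place on the ring carries the step, since the two change together in this pair, and plain phenyl on the amide-type nitrogen would provide a reference for both. Also open, on these data alone, are how an aryl ring carrying an amine or a carboxylic acid would read here, and how much the linker and the aryl group each contribute in compound 3 at 50%, where both differ from compound 1.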